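The source may report more compounds than this note shows. Statements on the series, on what has been measured and on what is new or still open speak of the compounds shown alone.

Compound 1 `CCn1c(C(=O)NCC(=O)OC)ccc1C(CC)(CC)c1ccc(OCS(=O)(=O)c2ccccc2)c(C)c1` gives > 50000 nM in a functional assay on PC-3 cells (Homo sapiens) for antiproliferative activity, read by MTT assay, with a stated time of 24 h (on this read-out lower numbers stand for stronger inhibition and higher numbers for weaker inhibition), which for compound 1 is a limit of the assay and not a number (the limit of > 50000 nM in this assay, at which 1 of the 2 values shown sits). Compound 2 `CCn1c(C(=O)N[C@@H](CC(=O)OC)C(=O)OC)ccc1C(CC)(CC)c1ccc(OCS(=O)(=O)c2ccccc2)c(C)c1` gives 6490 nM in this assay.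

Compound 1 thus stands at the weak end of the two values shown. Among the compounds with values here, the only measured step, an at least 7.7-fold lower number from compound 1 to compound 2 (0.88 log units; beyond the scatter), concerns a substituent placed at the same amide-type nitrogen. Compound 3 `CCn1c(C(=O)N[C@H](CO)C(C)C)ccc1C(CC)(CC)c1ccc(OCS(=O)(=O)c2ccccc2)c(C)c1` differs from compound 1 by 1-(hydroxymethyl)-2-methylpropyl in place of (methoxycarbonyl)methyl on an amide-type nitrogen. Within the data shown here, the expectation for this assay rests on the one step of an at least 7.7-fold lower number from compound 1 to compound 2 (0.88 log units; beyond the scatter) and is a lower number, of modest size: an at least 3.3-fold lower number from compound 1 to compound 3 (0.52 log units; beyond the scatter). Compound 3 is therefore estimated at 15000 nM, with a range from 4000 nM to 50000 nM.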

Compound 3, half-maximal inhibitory concentration: 7300 nM
For compound 3 the middle estimate is 2.1-fold (0.31 log units) above the measured one; the measured number falls inside the stated range.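

In this assay, a second and quite different substituent on the amide-type nitrogen also gives a lower number than the (methoxycarbonyl)methyl of compound 1 (an at least 6.8-fold lower number from compound 1 to compound 3 (0.83 log units; beyond the scatter)). The size of that step is bounded by compound 1, whose value is a limit and not a number: the limit of > 50000 nM in this assay, at which 1 of the 3 values shown sits. Thus 1,2-bis(methoxycarbonyl)ethyl is not the only group that brings this change, and 1-(hydroxymethyl)-2-methylpropyl stands level with it ((a 1.1-fold higher number from compound 2 to compound 3 (0.05 log units; within the scatter))).

As far as these compounds go, whether a carboxylic acid or an amine on this chain would hold that level remains open. So does the part played by the defined stereocentre of compound 3.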